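The compounds below may be only part of what the source reports. "The series", "measured", "known", "first", "only" and "open" are said of these compounds alone.

Compound 1, with the structure `CCc1ccc(-n2nc(-c3ccc(C(F)(F)F)cc3O)nc2-c2ccccc2O)cc1`, gives 107% in a functional assay on PC-12 cells (Rattus norvegicus) for cytotoxicity, read by MTT assay, with stated times of 2 h and 24 h, tested at 10 uM; on this read-out lower numbers stand for a weaker effect and higher numbers for a stronger effect at the one concentration tested. Compound 2, with the structure `Oc1cc(C(F)(F)F)ccc1-c1nc(-c2ccccc2O)n(-c2ccc(I)cc2)n1`, gives 105% in this assay. Among the compounds with values here, compound 2 and compound 1 are the only two compounds measured in this assay, and the step of a number 2 percentage points lower from compound 1 to compound 2 (within the scatter) lies within the scatter, so compound 2 stands level with compound 1 rather than apart from it.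

Compound 3, with the structure `Oc1cc(C(F)(F)F)ccc1-c1nc(-c2ccccc2O)n(-c2ccccc2Cl)n1`, has not yet been measured in this assay. It differs from compound 2 in one place: 2-chlorophenyl in place of 4-iodophenyl on an aromatic nitrogen.

Within the data shown here, the one measured step that bears on this change is the exchange at the same group on the aromatic nitrogen, from compound 1 to compound 2, and it gave only a shift within the scatter. The two measured compounds give no sign that the group on this nitrogen moves the read-out, so compound 3 is expected to show no step beyond the scatter, which would be a number 1 percentage points lower from compound 2 to compound 3 (within the scatter). Compound 3 is therefore estimated to give about 104% in this assay, between 90% and 118%.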

Compound 3, a percentage reported as activity, at one concentration (the size of the read-out at that concentration, not a potency): 102%
Beside the measured number, compound 3's estimate is 2 percentage points above it; low and high end bracket the measured number.
By their numbers in this assay, from the lowest: compounds 3, 2 and 1 (each within the scatter of the next).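

Compounds 1 and 2 varied only the group at the 4-position of the phenyl ring on the aromatic nitrogen, whereas compound 3 brings in a 2-chlorophenyl group, so a different substitution place on that ring now enters the comparison. In this assay this change still gives only a number 3 percentage points lower from compound 2 to compound 3 (within the scatter), and the comparison with the ethyl-bearing compound gives a number 5 percentage points lower from compound 1 to compound 3 (within the scatter), so the read-out does not separate 4-ethylphenyl, 4-iodophenyl and 2-chlorophenyl at this position. No measurement is available that could account for this level read-out.

Going by these compounds, all three groups are halogen- or alkyl-bearing phenyl rings, so it remains open whether a phenyl ring carrying an amine or a carboxylic acid, or a longer alkyl chain in place of the ring on this nitrogen, would stay level with them. On these data alone, the 2-hydroxyphenyl group and the trifluoromethyl-bearing hydroxyphenyl group are the same in all three compounds, so what happens to the read-out when either is changed also stays open.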